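From 2-chlorobenzyl to 2-bromobenzyl: compound 3

This account rests on a few compounds, and the source may have more. Where it says the series, first, only, none or still open, it means among the compounds named here.

In a functional assay on HCT-116 cells (Homo sapiens) for antiproliferative activity, read by MTT assay, with a stated time of 24 h (on this read-out lower numbers stand for stronger inhibition and higher numbers for weaker inhibition), compound 2 `COc1cc(OC)c(-c2coc3cc(OCc4ccccc4Cl)ccc3c2=O)cc1OC` gives 2450 nM and compound 1 `COc1cc(OC)c(-c2coc3cc(OCc4cccc(F)c4)ccc3c2=O)cc1OC` gives 4920 nM, two values within the scatter of each other. Compound 3 `COc1cc(OC)c(-c2coc3cc(OCc4ccccc4Br)ccc3c2=O)cc1OC` differs from compound 2 by bromo in place of chloro on an aromatic carbon, with bromo in place of chloro on an aromatic carbon, ortho to a large group. Within the data shown here, only one measured step bears on this change: a 2.0-fold lower number from compound 1 to compound 2 (0.30 log units; within the scatter), a halogen-bearing phenyl exchange that stays within the scatter. No step beyond the scatter is therefore expected in this assay. The expected step is a 1.1-fold higher number from compound 2 to compound 3 (0.04 log units; within the scatter). Compound 3 is estimated at 2700 nM, with an expected range of 1200 nM to 6000 nM.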

Compound 3, half-maximal inhibitory concentration: 4550 nM
Beside the measured number, compound 3's estimate is 1.7-fold (0.23 log units) below it, and the stated range covers the measured number.
By their numbers in this assay, from the lowest: compounds 2, 3 and 1 (each within the scatter of the next).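

In this assay bromo in place of chloro on an aromatic carbon, ortho to a large group, gives a 1.9-fold higher number from compound 2 to compound 3 (0.27 log units; within the scatter) and so does not separate the two halogens at this position. The wider exchange of the whole aryl group reads a 1.1-fold lower number from compound 1 to compound 3 (0.03 log units; within the scatter) and likewise separates nothing, so each of the three halogen-bearing benzyl groups lies within the scatter of the next. No measurement on hand offers an explanation for these values.

From the compounds shown here alone, whether an amine or a carboxylic acid on this aromatic ring, or a longer chain in place of the benzyl group, would give a step beyond the scatter stays open.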